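Exchanging one five-membered ring for another on compound 2

The compounds below may be only part of what the source reports. "The series", "measured", "known", "first", "only" and "open" are said of these compounds alone.

In an ADME assay on microsomes from liver (Rattus norvegicus, strain Sprague-Dawley) for pharmacokinetics, read by LC-MS, using NADPH, with a stated time of 45 min, tested at 1 uM (on this read-out higher numbers stand for fast clearance and lower numbers for slow clearance), compound 1 `COc1cc(OCc2ccnc(N)n2)cc2sc(N[C@H]3CCCC[C@@H]3O)nc12` gives 20 mL/min/kg, while compound 2 `COc1cc(OCc2ccnc(Nc3cnoc3)n2)cc2sc(N[C@H]3CCCC[C@@H]3O)nc12` gives 87 mL/min/kg, the higher of the two numbers. Compound 3 `COc1cc(OCc2ccnc(Nc3cn(C)nn3)n2)cc2sc(N[C@H]3CCCC[C@@H]3O)nc12` has 1-methyl-1H-1,2,3-triazol-4-yl in place of 1,2-oxazol-4-yl on a nitrogen on an aromatic ring. Among the measured compounds shown here, the only measured step, a 4.4-fold higher number from compound 1 to compound 2 (0.64 log units; beyond the scatter), lies beyond the scatter, but it adds a ring and does not exchange one, so it offers weak guidance. The step expected in this assay is a 1.5-fold lower number from compound 2 to compound 3 (0.16 log units; within the scatter), a small fall within the scatter. Compound 3 is estimated at 60 mL/min/kg, with an expected range from 30 mL/min/kg to 110 mL/min/kg.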

Compound 3, clearance: 25 mL/min/kg
Estimate against measurement, compound 3: 2.4-fold (0.38 log units) above; measured number below the stated range.
By their numbers in this assay, from the lowest: compounds 1 and 3 (each within the scatter of the next); then compound 2.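

At this nitrogen, the kind of five-membered ring matters, not just the presence of one. In this assay the exchange of 1,2-oxazol-4-yl for 1-methyl-1H-1,2,3-triazol-4-yl gives a 3.5-fold lower number from compound 2 to compound 3 (0.54 log units; beyond the scatter) and lies beyond the scatter. A ring on this nitrogen therefore need not raise clearance: a 1.3-fold higher number from compound 1 to compound 3 (0.10 log units; within the scatter) stays within the scatter. As far as these compounds go, whether a simple alkyl amine or an acetyl amide at this nitrogen would behave like either ring remains open, as does whether the methyl or the ring atoms drive the change. Nothing measured here explains the difference between the two rings.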